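The source may hold more compounds than are shown below. What is called first, only, known or untested is meant among the compounds shown, and "the series" means these compounds.

Measured compounds in an assay on CHO cells for displacement of a labelled ligand from prostaglandin D2 receptor 2 (Homo sapiens), read by scintillation counting; on this read-out higher numbers stand for weaker inhibition and lower numbers for stronger inhibition:

Compound 1, `CN(C)C(=O)c1cccc(C#Cc2cc(Cl)ccc2OCC(=O)O)c1`: 52 nM
Compound 2, `Cc1ccc(S(=O)(=O)NC(C)C)cc1C#Cc1cc(Cl)ccc1OCC(=O)O`: 3.4 nM
Compound 3, `O=C(O)COc1ccc(Cl)cc1C#Cc1ccc(F)cc1F`: 101 nM

Compound 2 gives the lowest number of the three in this assay, and its gaps to compound 1 and to compound 3 both lie beyond the usual scatter, so it is the strongest inhibitor shown here. Compound 4, `Cc1ccc(S(=O)(=O)N(C)C)cc1C#Cc1cc(Cl)ccc1OCC(=O)O`, keeps the core of compound 2 and differs in one place: dimethylamino in place of isopropylamino on a sulfonyl sulfur. For the measured compounds named here, no measured pair shows this change, so there is nothing to compare it with directly. The change is small, and the step from compound 2 to compound 4 is expected to stay within the scatter, a 1.5-fold higher number from compound 2 to compound 4 (0.17 log units; within the scatter). Compound 4 is therefore estimated at 5 nM, with a range from 2 nM to 15 nM.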

Compound 4, inhibition constant: 5 nM
Compound 4: the middle estimate sits on the measured number at the digits printed; the measured number falls inside the stated range.
By their numbers in this assay, from the lowest: compounds 2 and 4 (each within the scatter of the next); then compounds 1 and 3 (each within the scatter of the next).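

Putting dimethylamino in place of isopropylamino on a sulfonyl sulfur gives, in this assay, a 1.5-fold higher number from compound 2 to compound 4 (0.17 log units; within the scatter). For the compounds shown here, this is the first comparison here of compounds differing in one place, and it shows that losing the hydrogen-bond donor counted on isopropylamino does not move the number beyond the scatter. No supporting evidence is available to explain this result.

Still open, going by these compounds, is whether a longer chain on the nitrogen, as in butylamino, would fit as well. On these data alone, it is also open what a plain methyl on the sulfonyl sulfur, with no amine, would give.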